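The compounds below may be only part of what the source reports. "The series", "measured", "known", "first", "only" and "open" are said of these compounds alone.

Measured so far:
Compound 1, `CCOC(=O)c1c(C(F)(F)F)[n+]([O-])c2ccc(OC)cc2[n+]1[O-]`, gives 6000 nM in an ADME assay on J774 cells (Mus musculus) for cytotoxicity, read by MTT assay, with a stated time of 48 h; a higher number here means a weaker inhibitor, a lower number a stronger inhibitor.
Compound 2, `COC(=O)c1c(C(F)(F)F)[n+]([O-])c2ccc(C)cc2[n+]1[O-]`, gives 4000 nM in this assay.

Both compounds carry the same core with a trifluoromethyl group and an ester, and they differ in the ester chain and in the group on the carbon-only ring. Compound 1 gives 6000 nM and compound 2 gives 4000 nM in this assay; the gap between these two numbers is within the usual scatter of repeated measurements, so neither compound stands apart from the other on the data shown.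

Compound 3, `CCOC(=O)c1c(C(F)(F)F)[n+]([O-])c2ccccc2[n+]1[O-]`, has not yet been measured in this assay. It differs from compound 1 in one place: hydrogen in place of methoxy on an aromatic carbon. For the measured compounds named here, nothing among the measured compounds shows what removing this group does. The pair of compound 1 and compound 2 changes two places at once. With no guide, the step in this assay is expected to be small, in no particular direction, and not beyond the scatter. Compound 3 is therefore expected to give about 6000 nM, between 2500 nM and 15000 nM. This expectation amounts to the step of no change at the digits printed from compound 1 to compound 3 (within the scatter).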

Compound 3, half-maximal inhibitory concentration: 4000 nM
For compound 3 the middle estimate is 1.5-fold (0.18 log units) above the measured one, within the range that was stated.
By their numbers in this assay, from the lowest: compounds 2, 3 and 1 (each within the scatter of the next).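

For the compounds shown here, compound 1 and compound 3 differ only in one place, so this is the first comparison here that isolates a single change: hydrogen in place of methoxy on an aromatic carbon. That change gives a 1.5-fold lower number from compound 1 to compound 3 (0.18 log units; within the scatter) in this assay, so for this pair the read-out does not separate a methoxy group from a bare hydrogen at this position, and the cytotoxicity seen with compound 1 does not depend on the methoxy group being there. No measurement shown bears on why the two compounds read alike.

Going by these compounds, this single pair tests only hydrogen and methoxy on this core, so what a chlorine atom, an amine or a carboxylic acid would do at the same aromatic carbon remains open. The effect of the ester chain alone also remains open, since no two compounds shown differ in that place only, and neither a shorter comparison with the same ring group nor a longer chain such as a butyl ester can be judged from these numbers.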